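This account rests on a few compounds, and the source may have more. Where it says the series, first, only, none or still open, it means among the compounds named here.

Compound 3 `C=C(Br)C(=O)Nc1cccc(-c2cn3nc(CCc4ccccc4)sc3n2)c1` gives 3300 nM in a functional assay on HeLa cells (Homo sapiens) for inhibition, read by cell counting, with a stated time of 4 days (on this read-out higher numbers stand for weaker inhibition and lower numbers for stronger inhibition), the highest of the three numbers, with compound 2 `C=C(Br)C(=O)Nc1cccc(-c2cn3nc(Cc4ccc(Cl)cc4)sc3n2)c1` at 2700 nM and compound 1 `C=C(Br)C(=O)Nc1cccc(-c2cn3nc(Cc4cccc(OC)c4)sc3n2)c1` at 2500 nM. The steps among them, a 1.1-fold higher number from compound 1 to compound 2 (0.03 log units; within the scatter), a 1.3-fold higher number from compound 1 to compound 3 (0.12 log units; within the scatter) and a 1.2-fold higher number from compound 2 to compound 3 (0.09 log units; within the scatter), all stay within the scatter. Compound 4 `C=C(Br)C(=O)Nc1cccc(-c2cn3nc(-c4ccc(Cl)cc4)sc3n2)c1` differs from compound 3 by 4-chlorophenyl in place of phenethyl on an aromatic carbon. Among the compounds with values here, no measured step swaps phenethyl for 4-chlorophenyl on an aromatic carbon; the nearest relative is compound 2, which carries 4-chlorophenyl on a saturated chain carbon and sits within the scatter of compound 3. With each variation seen so far giving no step beyond the scatter, compound 4 is expected to give 2700 nM in this assay, a step of a 1.2-fold lower number from compound 3 to compound 4 (0.09 log units; within the scatter), within a range of 1200 nM to 6500 nM.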

Compound 4, half-maximal inhibitory concentration: 3000 nM
Beside the measured number, compound 4's estimate is 1.1-fold (0.05 log units) below it; the range from low to high includes it.
By their numbers in this assay, from the lowest: compounds 1, 2, 4 and 3 (each within the scatter of the next).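

Compound 4 carries 4-chlorophenyl on the aromatic carbon itself, without a saturated chain carbon, and in this assay the steps are a 1.1-fold lower number from compound 3 to compound 4 (0.04 log units; within the scatter) and a 1.1-fold higher number from compound 2 to compound 4 (0.05 log units; within the scatter) and a 1.2-fold higher number from compound 1 to compound 4 (0.08 log units; within the scatter), all within the scatter. Among these compounds, then, losing the saturated chain carbon gives no step beyond the scatter at this position, so aryl groups with and without that carbon cannot be told apart here. No evidence on this result is available. From the compounds shown here alone, whether an amine, a carboxylic acid or a longer chain at this position would give a step beyond the scatter remains open.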